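Amidoxime to Ethoxycarbamoyl on a Shared Indole-Pyrimidine Core

The source may hold more compounds than are shown below. What is called first, only, known or untested is meant among the compounds shown, and "the series" means these compounds.

Compound 2 `Cc1cc2c(C(=N)NO)cccc2n1-c1nc2c(c(NCc3cccc(O)c3)n1)CCC2` gives the lowest of the two numbers shown so far: in a functional assay on HCT-116 cells (Homo sapiens) for inhibition, read by luminescence and CellTiter-Glo, with a stated time of 72 h (a lower number here means a stronger inhibitor, a higher number a weaker inhibitor), compound 2 gives 1100 nM. Within the data shown here, its nearest neighbour is compound 1 `C/C=C/C(=O)Nc1cccc2c1cc(C)n2-c1nc2c(c(NCc3cccc(O)c3)n1)CCC2`, which in this assay gives 2400 nM; the step of a 2.2-fold lower number from compound 1 to compound 2 (0.34 log units; beyond the scatter) is the only measured step and it lies beyond the scatter, though it is modest.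

Compound 3 `CCONC(=O)c1cccc2c1cc(C)n2-c1nc2c(c(NCc3cccc(O)c3)n1)CCC2` differs from compound 2 at the same aromatic carbon: a group of 6 heavy atoms (3 carbon, 1 nitrogen, 2 oxygen; no ring) in place of a group of 4 heavy atoms (1 carbon, 2 nitrogen, 1 oxygen; no ring), on an aromatic carbon. Among the measured compounds shown here, the one measured step does bear loosely on this change, since it too exchanges the group on that carbon, but it does not involve the ethoxycarbamoyl group, so the direction of the new step cannot be taken from it. Given that the two groups swapped between compound 1 and compound 2 produced only a modest step, the step of a 1.6-fold higher number from compound 2 to compound 3 (0.21 log units; within the scatter) is expected to be small, with a slight lean toward a higher number. Compound 3 is therefore estimated at 1800 nM in this assay, within a range from 700 nM to 4500 nM.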

Compound 3, half-maximal inhibitory concentration: 600 nM
For compound 3 the middle estimate is 3.0-fold (0.48 log units) above the measured one; the whole stated range lies above it.
By their numbers in this assay, from the lowest: compounds 3 and 2 (each within the scatter of the next); then compound 1.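

At this aromatic carbon, this assay gives a 1.8-fold lower number from compound 2 to compound 3 (0.26 log units; within the scatter), so ethoxycarbamoyl, with 6 heavy atoms and 1 hydrogen-bond donor, cannot be told apart from the group of compound 2, with 4 heavy atoms and 3 hydrogen-bond donors. Against the ((prop-1-en-1-yl)carbonyl)amino group the picture is clearer, with a 4.0-fold lower number from compound 1 to compound 3 (0.60 log units; beyond the scatter), so the position now shows a separation that is still modest but rests on two different groups, each set apart from that of compound 1, and the difference in hydrogen-bond donor count between the groups of compound 2 and compound 3 does not separate those two compounds. Nothing available explains any of these steps.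

Going by these compounds, it remains open whether a longer chain on the oxygen, such as propoxycarbamoyl, or a smaller methoxycarbamoyl group would stand apart from compound 3 in this assay. A carboxylic acid or a primary amine on this same aromatic carbon would likewise show how far the position can be changed while the shared core stays fixed.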